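Replacing a Benzyl Side Chain on a Shared Core

This account rests on a few compounds, and the source may have more. Where it says the series, first, only, none or still open, it means among the compounds named here.

Measured compounds:
compound 1, `CC1=C(N2CC2)C(=O)C(Cc2ccccc2)=C(N2CC2)C1=O`: in a functional assay on L1210 cells (Mus musculus), with a stated time of 1 days (on this read-out higher numbers stand for higher potency (the scale is a negative logarithm) and lower numbers for lower potency), compound 1 gives 4.26
compound 2, `CCC1=C(N2CC2)C(=O)C(C(COC(N)=O)OC)=C(N2CC2)C1=O`: compound 2 gives 4.92
compound 3, `COCCC1=C(N2CC2)C(=O)C(CCOC)=C(N2CC2)C1=O`: compound 3 gives 4.71

Of these three numbers, compound 1 has the lowest. Compound 3 is nearest to it, yet its number is higher by more than the usual scatter, and compound 2 is furthest, also beyond the scatter. All three share the same core and differ only in the side chains on it.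

The step to compound 4, `CC1=C(N2CC2)C(=O)C(C(C)COC(N)=O)=C(N2CC2)C1=O`, changes one of those side chains: a group of 7 heavy atoms (4 carbon, 1 nitrogen, 2 oxygen; no ring) in place of a group of 7 heavy atoms (7 carbon; one six-membered aromatic ring of carbon only), on a double-bonded ring carbon. Going by the values given here, no measured pair shows exactly this exchange, so the size of the step has to be judged from the three values alone. Both compound 2 and compound 3, which do not carry a benzyl, sit above compound 1 in this assay, so a rise is expected rather than a fall. Compound 4 is estimated at 4.8, with a range from 4.3 to 5.3. The expected step is a number 0.54 log units higher from compound 1 to compound 4 (beyond the scatter) in this assay.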

Compound 4, logarithm of the reciprocal of the active concentration, log(1/C): 5.31
Compound 4: the middle estimate sits 0.51 log units below what was measured, outside the stated range (above it).
By their numbers in this assay, from the lowest: compound 1; then compounds 3 and 2 (each within the scatter of the next); then compound 4.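

In this assay, going by these compounds alone, exchanging the benzyl for this ring-free side chain on the double-bonded ring carbon gives a number 1.05 log units higher from compound 1 to compound 4 (beyond the scatter), the first change at this position that can be read on its own. Both groups hold 7 heavy atoms, so the rise comes without a change in that count, and the aromatic ring is not needed at this position for a high number in this assay. The data offer no explanation of why this exchange raises the number.

The new chain brings nitrogen, oxygen, a hydrogen-bond donor and hydrogen-bond acceptors all at once, so the compounds shown cannot tell which of these goes with the rise. A plain butyl chain, or a chain ending in a hydroxyl group or an amine, on the same ring carbon would help to separate them.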